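The source may report more compounds than this note shows. Statements on the series, on what has been measured and on what is new or still open speak of the compounds shown alone.

In an assay on CHO cells for displacement of a labelled ligand from adenosine receptor A1 (Homo sapiens), read by scintillation counting, with a stated time of 60 min, tested at 10 uM (a lower number here means less inhibition, a higher number more inhibition at the concentration tested (going by the name of the read-out)), compound 1 `COc1cccc2cc(C(=O)NCC(=O)O)c(=O)oc12` gives 27%, compound 2 `COCCNC(=O)c1cc2cccc(OC)c2oc1=O` gives 45%, and compound 3 `COc1cccc2cc(C(=O)NCC(O)CO)c(=O)oc12` gives 14%.

Compound 3 stands lowest of the three numbers, with compound 1 nearest and compound 2 furthest. The move to compound 4 `COc1cccc2cc(C(=O)NCCO)c(=O)oc12` is hydrogen in place of hydroxymethyl on a saturated chain carbon bound to an oxygen on a saturated carbon and a saturated chain carbon. Going by the values given here, two measured steps touch the same chain: a number 13 percentage points lower from compound 1 to compound 3 (beyond the scatter) and a number 31 percentage points lower from compound 2 to compound 3 (beyond the scatter), both toward a lower number when the 1,2-dihydroxyethyl group entered. Among the compounds with values here, no measured step covers the loss of a hydroxymethyl alone. Compound 4 keeps a single hydroxy group on a shorter chain; a modest rise in this assay is expected, staying short of compound 2. Compound 4 is therefore estimated at 25%, from 10% to 42%, and the expected change is a number 11 percentage points higher from compound 3 to compound 4 (beyond the scatter).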

Compound 4, a percentage reported as inhibition, at one concentration (the size of the read-out at that concentration, not a potency): 12%
Estimate against measurement, compound 4: 13 percentage points above; measured number inside the range.
By their numbers in this assay, from the lowest: compounds 4 and 3 (each within the scatter of the next); then compound 1; then compound 2.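

In this assay the loss of the hydroxymethyl, taking 2,3-dihydroxypropyl to 2-hydroxyethyl, changes little (a number 2 percentage points lower from compound 3 to compound 4 (within the scatter)), so the second hydroxy group of compound 3 is not needed for its low number. Capping the remaining hydroxy group with methyl matters far more, as the step back from the ether shows (a number 33 percentage points lower from compound 2 to compound 4 (beyond the scatter)), while hydroxymethyl in place of carboxy also counts (a number 15 percentage points lower from compound 1 to compound 4 (beyond the scatter)). Nothing available explains these steps.

As far as these compounds go, whether an amine or a longer chain ending in hydroxy would keep the number this low remains open.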